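The source may report more compounds than this note shows. Statements on the series, on what has been measured and on what is new or still open speak of the compounds shown alone.

In a functional assay on MGC-803 cells (Homo sapiens) for inhibition, read by MTT assay, with a stated time of 72 h (on this read-out lower numbers stand for stronger inhibition and higher numbers for weaker inhibition), compound 1 `COc1ccc(Cn2cc(CSC(=S)N3CCN(C(=O)OCc4ccccc4)CC3)nn2)cc1` gives 23800 nM, the second highest of the three numbers measured: compound 3 `Cc1ccc(-n2cc(CSC(=S)N3CCN(C(=O)OC(C)(C)C)CC3)nn2)cc1` gives 48300 nM, and compound 2 `Cc1ccc(Cn2cc(CSC(=S)N3CCN(C(=O)OC(C)(C)C)CC3)nn2)cc1` gives 3490 nM. Compound 4 `COc1cc(Cn2cc(CSC(=S)N3CCN(C(=O)OCc4ccccc4)CC3)nn2)cc(OC)c1OC` differs from compound 1 in one place: 3,4,5-trimethoxyphenyl in place of 4-methoxyphenyl on a saturated chain carbon bound to an aromatic nitrogen. For the measured compounds named here, none of the measured steps bears on this change; the only single-point step, a 14-fold higher number from compound 2 to compound 3 (1.14 log units; beyond the scatter), concerns the link to the aromatic nitrogen rather than the substitution of the phenyl ring, so it offers no guide. Going by the values given here, with no comparable step measured, compound 4 is expected to sit near compound 1, with any shift in this assay likely modest, expressed as a 1.6-fold lower number from compound 1 to compound 4 (0.20 log units; within the scatter). Compound 4 is therefore estimated at 15000 nM, in the range 4000 nM to 50000 nM.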

Compound 4, half-maximal inhibitory concentration: 10900 nM
For compound 4 the middle estimate is 1.4-fold (0.14 log units) above the measured one, within the range that was stated.
By their numbers in this assay, from the lowest: compound 2; then compound 4; then compound 1; then compound 3.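

In this assay, the ring on the saturated chain carbon bound to an aromatic nitrogen proves responsive to its substitution: 3,4,5-trimethoxyphenyl in place of 4-methoxyphenyl gives a modest step beyond the scatter (a 2.2-fold lower number from compound 1 to compound 4 (0.34 log units; beyond the scatter)). For the compounds shown here, this is the first measured sign that this ring's substituents affect the number, and nothing at hand accounts for the shift. Going by these compounds, it remains open whether all three methoxy groups are needed, and how a 4-hydroxyphenyl or 4-aminophenyl group would compare. On these data alone, the same change on compound 2 also remains open.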